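Replacing a carbamate with a fluorinated cycloalkyl substituent

This account rests on a few compounds, and the source may have more. Where it says the series, first, only, none or still open, it means among the compounds named here.

Of the compounds shown here, three sharing one core have been measured in a functional assay on isolated protein for agonist activity at Glucose-dependent insulinotropic receptor (Rattus norvegicus), read by HTRF and cAMP accumulation; on this read-out lower numbers stand for smaller maximal responses and higher numbers for larger maximal responses. Compound 1 `CC(C)OC(=O)N1CCC(O[C@H]2CC[C@H](Oc3ccc(S(C)(=O)=O)nc3)CC2)CC1` gives 125%, compound 2 `CC(C)(C)OC(=O)N1CCC(O[C@H]2CC[C@H](Oc3cnc(C#N)cn3)CC2)CC1` gives 100%, and compound 3 `CC1(OC(=O)N2CCC(O[C@H]3CC[C@H](Oc4cnc(S(C)(=O)=O)cn4)CC3)CC2)CC1` gives 123%. Compound 3 thus stands second highest of the three: compound 1 is its nearest neighbour, within the scatter, while compound 2 lies furthest from it, beyond the scatter. Compound 4 `CS(=O)(=O)c1cnc(O[C@H]2CC[C@H](OC3CCN(CC4(C(F)(F)F)CCCC4)CC3)CC2)cn1` differs from compound 3 in one place: a group of 10 heavy atoms (7 carbon, 3 fluorine; one five-membered non-aromatic ring of carbon only) in place of a group of 7 heavy atoms (5 carbon, 2 oxygen; one three-membered non-aromatic ring of carbon only), on an amine nitrogen in a ring. Within the data shown here, no measured pair shows a change of this kind. The step of a number 15 percentage points lower from compound 3 to compound 4 (beyond the scatter) is expected to be small, tending downward but most likely staying within the scatter. Compound 4 is therefore expected to give about 108% in this assay, within a range from 80% to 130%.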

Compound 4, largest response reached (Emax), in percent of the reference or control that the assay uses: 88%
The estimate for compound 4 lay 20 percentage points above the measured number; measured number inside the range.
By their numbers in this assay, from the lowest: compound 4; then compound 2; then compounds 3 and 1 (each within the scatter of the next).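

In this assay, the change on the amine nitrogen gives a number 35 percentage points lower from compound 3 to compound 4 (beyond the scatter), the first step read at this position. Among these compounds, the carbamate of the earlier compounds is therefore not required for a response, since compound 4 still gives 88%, but this replacement does not keep the level of compound 3. Nothing measured here explains the drop. On these data alone, it remains open whether the loss follows the missing carbonyl, the trifluoromethyl or the five-membered ring; an amide or a cyclopentylmethyl group on that nitrogen would help separate these.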